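This account rests on a few compounds, and the source may have more. Where it says the series, first, only, none or still open, it means among the compounds named here.

Compound 1 `CC(=O)N1CCC(S(=O)(=O)c2ccc(CNC(=O)N3Cc4ccncc4C3)cc2)CC1` and compound 2 `CN1CCC(S(=O)(=O)c2ccc(CNC(=O)N3Cc4ccncc4C3)cc2)CC1` share one core and differ only at the ring amine that carries the sulfonyl group. In an assay on isolated protein for inhibition of Nicotinamide phosphoribosyltransferase (Homo sapiens), read by mass spectrometry, with stated times of 15 min and 30 min (a higher number here means a weaker inhibitor, a lower number a stronger inhibitor), compound 1 gives 83 nM, and in the same assay compound 2 gives 48 nM. The step of a 1.7-fold lower number from compound 1 to compound 2 (0.24 log units; within the scatter) is the only one measured so far, and it does not separate the two compounds beyond the scatter. On the numbers shown, compound 2 has the lowest value of the two, with compound 1 close to it.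

Compound 3 `O=C(NCc1ccc(S(=O)(=O)N2CCOCC2)cc1)N1Cc2ccncc2C1` has not yet been measured. It differs from compound 2 by morpholin-4-yl in place of 1-methylpiperidin-4-yl on a sulfonyl sulfur. Among the measured compounds shown here, the one measured step changes only the group on the ring nitrogen and leaves the ring itself in place, so it bears on this change only loosely: it shows that small edits at this position move this assay little. The change to compound 3 is larger, swapping the whole ring, and nothing measured tells its direction. The expected step of a 2.3-fold higher number from compound 2 to compound 3 (0.36 log units; beyond the scatter) is therefore estimated as modest, with wide uncertainty. For compound 3 the estimate in this assay is 110 nM, within a range from 30 nM to 450 nM.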

Compound 3, half-maximal inhibitory concentration: 71 nM
Compound 3: middle estimate off by 1.5-fold (0.19 log units), on the high side; the range from low to high includes it.
By their numbers in this assay, from the lowest: compounds 2, 3 and 1 (each within the scatter of the next).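

In this assay, the step of a 1.5-fold higher number from compound 2 to compound 3 (0.17 log units; within the scatter) exchanges the whole 1-methylpiperidin-4-yl group on the sulfonyl sulfur for morpholin-4-yl, yet it stays within the scatter. The step of a 1.2-fold lower number from compound 1 to compound 3 (0.07 log units; within the scatter), with morpholin-4-yl in place of 1-acetylpiperidin-4-yl, also stays within the scatter, so these three compounds cannot be told apart in this assay, and the small effect earlier seen for a change on the ring nitrogen now also holds for these exchanges of the whole group. No measurement at hand explains this result.

On these data alone, all three compounds carry a six-membered non-aromatic ring on the sulfonyl sulfur, so it remains open whether a different kind of group there, such as an open-chain amine or a carboxylic acid, would move the number further. Only the group on the sulfonyl sulfur varies among these compounds, so they also leave open how the number would respond to a change elsewhere in the shared core.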